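The source may hold more compounds than are shown below. What is called first, only, known or untested is meant among the compounds shown, and "the series" means these compounds.

Going by the values given here, in an ADME assay on L929 cells (Mus musculus) for cytotoxicity, read by resazurin assay, with a stated time of 72 h (a higher number here means a weaker inhibitor, a lower number a stronger inhibitor), compound 3 (`Cc1cccc(C(=O)/C=C/c2ccc3c(c2)B(O)OC3)c1`) gives 8.56 ug/mL as the only actual number so far. Compound 1 (`O=C(/C=C/c1ccc2c(c1)B(O)OC2)c1ccccc1O`) gives > 10 ug/mL as a limit, not a number. Compound 2 (`O=C(/C=C/c1ccc2c(c1)B(O)OC2)c1ccccc1`) likewise gives > 10 ug/mL as a limit, not a number.

Compound 4 (`O=C(/C=C/c1ccc2c(c1)B(O)OC2)c1ccc(F)cc1`) has 4-fluorophenyl in place of 3-methylphenyl on a carbonyl carbon. The measured steps that bear on this group are an at least 1.1-fold lower number from compound 2 to compound 3 (0.06 log units; that floor lies within the scatter) and an at least 1.1-fold lower number from compound 1 to compound 3 (0.06 log units; that floor lies within the scatter) together with a step that the two limits leave unreadable from compound 1 to compound 2 on the same group. Neither floor goes beyond the scatter and the third step gives no size, so no step beyond the scatter is expected in this assay in either direction. These steps cover other substituents, so they offer only a loose guide to the fluorine-bearing group in compound 4.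

The estimated change is a 1.1-fold higher number from compound 3 to compound 4 (0.05 log units; within the scatter) and would stay within the scatter. A report of compound 4 as a limit is also expected to be about as likely as a number, given the limit of > 10 ug/mL in this assay, at which 2 of the 3 values shown sit, as the outcome so far. For compound 4 the estimated value is 9.5 ug/mL with an expected range from 4.5 ug/mL to 20 ug/mL in this assay for now.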

Compound 4, half-maximal inhibitory concentration: > 10 ug/mL
Compound 4: a limit, no number; the forecaster's own chance of this, stated with the estimate: 50%; at least 1.0-fold (0.02 log units) between middle value and limit.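

In this assay, replacing 3-methylphenyl with 4-fluorophenyl on a carbonyl carbon gives an at least 1.1-fold higher number from compound 3 to compound 4 (0.06 log units; that floor lies within the scatter), so this exchange of one substituted phenyl group for another shows no readable step beyond the scatter. Going by these compounds alone, compound 4 gives a limit and not a number, which means the only measured number still belongs to compound 3, and this position has so far yielded a lower bound rather than a measured size of effect: the limit of > 10 ug/mL in this assay, at which 3 of the 4 values shown sit. The steps from compound 1 to compound 4 and from compound 2 to compound 4 cannot be read, as each joins two limits, so neither of these two exchanges has a measurable size here.

The actual values of compound 1, compound 2 and compound 4 stay open, and no order among these three can be given in this assay. Also open, on these data alone, is whether an amine or a carboxylic acid on the phenyl group, or a longer chain in its place on the carbonyl carbon, would give a step beyond the scatter in either direction.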